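The source may report more compounds than this note shows. Statements on the series, on what has been measured and on what is new or still open speak of the compounds shown alone.

Compound 1 `C=C[C@@](C)(/C=C/c1ccc(Nc2ccc(F)cc2)cc1)CCC=C(C)C`: > 52000 nM (a limit)
Compound 2 `C=C[C@@](C)(/C=C/c1ccc(-c2ccccc2)cc1)CCC=C(C)C`: > 52000 nM (a limit)

In a functional assay on HepG2 cells (Homo sapiens) for cytotoxicity, with a stated time of 72 h (on this read-out lower numbers stand for an effect already at smaller amounts and higher numbers for an effect only at larger amounts of compound), compound 2 gives > 52000 nM, which is a limit of the assay and not a number. Compound 1 gives > 52000 nM, which is also a limit. The two compounds therefore share (the limit of > 52000 nM in this assay, at which 2 of the 2 values shown sit). Going by the values given here, the one measured step is a step that the two limits leave unreadable from compound 1 to compound 2, and it offers no size to carry forward.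

Compound 3 `C=C[C@@](C)(/C=C/c1ccc(-c2ccc(Cl)c(Cl)c2)cc1)CCC=C(C)C` has 3,4-dichlorophenyl in place of phenyl, on an aromatic carbon para to a large group: 3,4-dichlorophenyl in place of phenyl on an aromatic carbon. No measured number shows what such a change does in this assay, so no direction can be drawn from the data, and compound 3 is expected to stay close to the limit reached by compound 2. The expected step is an at least 1.1-fold lower number from compound 2 to compound 3 (0.06 log units; that floor lies within the scatter), estimated to remain within the usual scatter. The estimated value of compound 3 is 45000 nM, expected to fall between 18000 nM and 80000 nM.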

Compound 3, half-maximal effective concentration: > 52000 nM
Compound 3 was reported as a limit (the forecaster's own chance of this, stated with the estimate: 70%); middle value at least 1.1-fold (0.06 log units) from the limit.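

Compound 1, compound 2 and compound 3 are all reported only as limits in this assay, so none of the steps among them can be read: the limit of > 52000 nM in this assay, at which 3 of the 3 values shown sit. The compounds shown leave open whether any group at this aromatic carbon changes the read-out, and by how much.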